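A few compounds are considered here, and "the series" means these few. Any claim that something is new, unique, unknown or untested is made for them only; others in the source may bear on it.

Measured in a functional assay on ECa-109 cells for inhibition, with ECa-109 cell line (Homo sapiens) as the target, read by sulforhodamine B assay; a higher number here means a weaker inhibitor, a lower number a stronger inhibitor:

- Compound 1 `O=C1C=C(NC2CCCC2)C(=O)c2c1nc1n2[C@H]2OC[C@@H](O)[C@H]2OC1` gives > 16000 nM, a limit of the assay
- Compound 2 `CCOc1ccc(NC2=CC(=O)c3nc4n(c3C2=O)[C@H]2OC[C@@H](O)[C@H]2OC4)cc1` gives 3210 nM
- Compound 3 `CCOc1ccccc1NC1=CC(=O)c2nc3n(c2C1=O)[C@H]1OC[C@@H](O)[C@H]1OC3` gives 4630 nM

Compound 3 gives 4630 nM and sits level with compound 2 at 3210 nM, as a 1.4-fold higher number from compound 2 to compound 3 (0.16 log units; within the scatter) lies within the scatter. Compound 1 is known only through its limit of > 16000 nM.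

Compound 4 `O=C1C=C(Nc2cccc(Cl)c2)C(=O)c2c1nc1n2[C@H]2OC[C@@H](O)[C@H]2OC1` keeps the shared core and places 3-chlorophenyl in place of 2-ethoxyphenyl on the amine nitrogen: 3-chlorophenyl in place of 2-ethoxyphenyl on an amine nitrogen.

Two measured steps show that a substituted phenyl counts for more than a cyclopentyl at this place: an at least 4.9-fold lower number from compound 1 to compound 2 (0.69 log units; beyond the scatter) and an at least 3.4-fold lower number from compound 1 to compound 3 (0.53 log units; beyond the scatter). Compound 4 stays in that phenyl group. Moving the ethoxy group, seen in compound 3 at 4630 nM, made no difference beyond the scatter, and no measured step replaces ethoxy with chlorine. No step beyond the scatter is therefore expected in this assay, and no direction is favoured.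

The expected change is a 1.2-fold lower number from compound 3 to compound 4 (0.06 log units; within the scatter).

For compound 4 the estimate is 4000 nM, with an expected range from 1500 nM to 12000 nM.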

Compound 4, half-maximal inhibitory concentration: 4690 nM
The estimate for compound 4 lay 1.2-fold (0.07 log units) below the measured number, within the range that was stated.
By their numbers in this assay, from the lowest: compounds 2, 3 and 4 (each within the scatter of the next). At a limit, above all of these: compound 1.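

In this assay, the 3-chlorophenyl group on the amine nitrogen stands level with both ethoxyphenyl groups: a 1.0-fold higher number from compound 3 to compound 4 (0.01 log units; within the scatter), and a 1.5-fold higher number from compound 2 to compound 4 (0.16 log units; within the scatter). The earlier compounds shown here carried ethoxyphenyl groups only, whereas this result shows that the advantage over cyclopentyl also holds with chlorine in place of ethoxy on the phenyl ring, with an at least 3.4-fold lower number from compound 1 to compound 4 (0.53 log units; beyond the scatter). The size of that step remains a bound, since compound 1 is known only through a limit: the limit of > 16000 nM in this assay, at which 1 of the 4 values shown sits.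

On these data alone, the effect of an unsubstituted phenyl, or of a phenyl carrying an amine or a carboxylic acid, on the amine nitrogen remains open. As far as these compounds go, it also remains open whether any phenyl substituent can move the number beyond the scatter of these three compounds.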